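The source may hold more compounds than are shown below. What is called first, only, known or untested is meant among the compounds shown, and "the series" means these compounds.

Of the compounds shown here, three that share one core have been tested in a functional assay on MGC-803 cells (Homo sapiens) for cytotoxicity, read by MTT assay, with a stated time of 72 h; a lower number here means a stronger inhibitor, a higher number a weaker inhibitor. Compound 1 `O=C1C(=Cc2ccc(O)cc2)C(=O)N(c2ccc(Cl)cc2)N1c1ccc(Cl)cc1` gives 19500 nM, compound 2 `COc1cccc(C=C2C(=O)N(c3ccc(Cl)cc3)N(c3ccc(Cl)cc3)C2=O)c1` gives 26600 nM and compound 3 `O=C1C(=Cc2ccc(F)cc2F)C(=O)N(c2ccc(Cl)cc2)N1c1ccc(Cl)cc1` gives 35700 nM. These three values lie within the usual scatter of one another, so compound 3 cannot be separated from the other two.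

The next compound to be tested is compound 4 `O=C1C(=Cc2ccco2)C(=O)N(c2ccc(Cl)cc2)N1c1ccc(Cl)cc1`. It carries furan-2-yl in place of 2,4-difluorophenyl on a double-bonded chain carbon bound to a double-bonded ring carbon, a swap counted as furan-2-yl in place of 2,4-difluorophenyl on a double-bonded chain carbon bound to a double-bonded ring carbon. The entering group brings one five-membered aromatic ring with 1 hetero atom.

All three measured steps change the group at this same place, so each bears on the new swap. They are a 1.4-fold higher number from compound 1 to compound 2 (0.13 log units; within the scatter), a 1.8-fold higher number from compound 1 to compound 3 (0.26 log units; within the scatter) and a 1.3-fold higher number from compound 2 to compound 3 (0.13 log units; within the scatter), and none goes beyond the scatter. None of them introduces a five-membered aromatic ring, however, so the data do not test furan-2-yl directly.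

On this evidence, no change beyond the scatter is expected in this assay. The expected step is a 1.3-fold lower number from compound 3 to compound 4 (0.12 log units; within the scatter). For compound 4 the estimated value is 27000 nM, with an expected range from 12000 nM to 60000 nM.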

Compound 4, half-maximal inhibitory concentration: 12800 nM
Compound 4: the middle estimate sits 2.1-fold (0.32 log units) above what was measured, and the stated range covers the measured number.
By their numbers in this assay, from the lowest: compounds 4, 1, 2 and 3 (each within the scatter of the next, the first and the last beyond it).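

In this assay, for the compounds shown here, furan-2-yl gives the first steps at this place that go beyond the scatter, both of them modest: a 2.8-fold lower number from compound 3 to compound 4 (0.45 log units; beyond the scatter) and a 2.1-fold lower number from compound 2 to compound 4 (0.32 log units; beyond the scatter). The group on the double-bonded chain carbon can therefore shift the number measurably, which the three earlier compounds could not show, although the shift is only partial, with a 1.5-fold lower number from compound 1 to compound 4 (0.18 log units; within the scatter) leaving furan-2-yl unseparated from 4-hydroxyphenyl. No measurement shown here accounts for this difference.

The swap from 2,4-difluorophenyl to furan-2-yl alters several things at once, including the ring size, the heavy-atom count, the loss of fluorine and the arrival of a ring oxygen, so the compounds shown leave open which of these matters. Thiophene-2-yl, which has sulfur in place of the ring oxygen, and unsubstituted phenyl, which has no fluorine and no ring hetero atom, would help pull these changes apart, while an amine or a carboxylic acid on the ring would show how far this position tolerates a very different group.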